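Amino for Nitro on the Benzimidazole of Compound 3

The compounds below may be only part of what the source reports. "The series", "measured", "known", "first", "only" and "open" are said of these compounds alone.

Measured compounds:
Compound 1 `CCn1cc(-c2nc3ccccc3[nH]2)c(=O)c2cc(F)c(N3CCN(C)CC3)cc21`: 36700 nM
Compound 2 `CCn1cc(-c2nc3ccccc3o2)c(=O)c2cc(F)c(N3CCN(C)CC3)cc21`: 87400 nM
Compound 3 `CCn1cc(-c2nc3ccc([N+](=O)[O-])cc3[nH]2)c(=O)c2cc(F)c(N3CCN(C)CC3)cc21`: 2500 nM

The measurements come from a functional assay on KB cells (Homo sapiens) for cytotoxicity, read by MTT assay, with a stated time of 48 h; a higher number here means a weaker inhibitor, a lower number a stronger inhibitor. Compound 3 holds the lowest of the three numbers; compound 1 is nearest, and the step of a 15-fold lower number from compound 1 to compound 3 (1.17 log units; beyond the scatter) separates them, while compound 2 stands furthest. The other measured step, a 2.4-fold higher number from compound 1 to compound 2 (0.38 log units; beyond the scatter), is modest by comparison.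

Compound 4 `CCn1cc(-c2nc3ccc(N)cc3[nH]2)c(=O)c2cc(F)c(N3CCN(C)CC3)cc21` is not yet measured. It differs from compound 3 in one place: amino in place of nitro on an aromatic carbon. For the measured compounds named here, only one measured step touches the same position, the one from compound 1 to compound 3, where nitro replaced hydrogen, a large step. Going by the values given here, nothing measured shows an amino group there, so the step that carries the nitro away is the only guide, and the data do not say whether an amino group recovers part of it. On that basis compound 4 is expected to fall between compound 1 and compound 3, with a 4.0-fold higher number from compound 3 to compound 4 (0.60 log units; beyond the scatter) expected. The estimate for compound 4 in this assay is 10000 nM, within a range from 2000 nM to 50000 nM.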

Compound 4, half-maximal inhibitory concentration: > 50000 nM
Compound 4: only a limit was reported (the forecaster's own chance of this, stated with the estimate: 5%); middle value at least 5.0-fold (0.69 log units) away from the limit.
By their numbers in this assay, from the lowest: compound 3; then compound 1; then compound 2.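

In this assay compound 4 is reported only as a limit of the assay: the limit of > 50000 nM in this assay, at which 1 of the 4 values shown sits.

Amino in place of nitro gives an at least 20-fold higher number from compound 3 to compound 4 (1.30 log units; beyond the scatter), so the low number of compound 3 is not shared by the amino group at this aromatic carbon. Amino in place of hydrogen gives an at least 1.3-fold higher number from compound 1 to compound 4 (0.13 log units; that floor lies within the scatter), which shows no lowering of the number by amino, though how far the true value lies past that floor stays unknown, and the step from compound 2 to compound 4 cannot be read.

The compounds shown leave open whether a nitrile, a trifluoromethyl or an acetamide on this carbon would lower the number as nitro does. They also leave open whether nitro would have a similar effect on the core of compound 2.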